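The source may hold more compounds than are shown below. What is called first, only, known or untested is meant among the compounds shown, and "the series" means these compounds.

Compound 1 `C=CC1=C(C(=O)Nc2ccccc2OC)C(c2ccc(F)cc2)OC1` is the methoxy-bearing anilide of the series. In a functional assay on QGY7701 cells (Homo sapiens) for cytotoxicity, read by MTT assay, with a stated time of 24 h (a lower number here means a stronger inhibitor, a higher number a weaker inhibitor), compound 1 gives 52800 nM, the highest of the two numbers in the set. The nearest number is that of compound 3 `C=CC1=C(C(=O)NC2CCCCC2)C(c2ccc(OC)c(OC)c2)OC1`, which gives 7490 nM in this assay, a gap beyond the scatter. Compound 2 `C=CC1=C(C(=O)Nc2ccccc2OC)C(c2ccc(Cl)c(Cl)c2)OC1` gives no number in this assay but only a limit, > 100000 nM.

Within the data shown here, the only measured step is an at least 1.8-fold higher number from compound 1 to compound 2 (0.27 log units; that floor lies within the scatter), a change of the aryl group on the saturated ring carbon; its floor lies within the scatter, and one of the values concerned is a limit (the limit of > 100000 nM in this assay, at which 1 of the 3 values shown sits).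

Compound 4 `C=CC1=C(C(=O)Nc2ccccc2)C(c2ccc(F)cc2)OC1` differs from compound 1 by hydrogen in place of methoxy on an aromatic carbon. Among the measured compounds shown here, no measured step touches the anilide ring, and the one measured step, on the other ring, shows at most a change that cannot be separated from the scatter. Nothing in the measured set therefore points to a step in either direction for this change, and the expectation is a step of a 1.1-fold lower number from compound 1 to compound 4 (0.02 log units; within the scatter), within the scatter. Compound 4 is thus estimated at 50000 nM in this assay, with a range from 15000 nM to 150000 nM.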

Compound 4, half-maximal inhibitory concentration: 46700 nM
Compound 4: middle estimate off by 1.1-fold (0.03 log units), on the high side, within the range that was stated.
By their numbers in this assay, from the lowest: compound 3; then compounds 4 and 1 (each within the scatter of the next). At a limit, above all of these: compound 2.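

Hydrogen in place of methoxy on an aromatic carbon, ortho to a large group, gives in this assay a 1.1-fold lower number from compound 1 to compound 4 (0.05 log units; within the scatter), the first reading of any change on the anilide ring. Among these compounds, with 4-fluorophenyl held constant, the change from 2-methoxyphenyl to phenyl therefore gives no step that can be separated from the scatter, and this pair shows that the number does not depend on the methoxy group at this place. Nothing measured in the series bears on why this step is so small.

Among the compounds shown here, whether an amine, a carboxylic acid or a longer chain such as butoxy at the same place would also leave the number within the scatter of compound 1 remains open, since hydrogen and methoxy are the only two groups compared there. Also open, from the compounds shown here alone, is whether the change reads the same with 3,4-dichlorophenyl in place of 4-fluorophenyl, the aryl group of compound 2, whose result is a limit and not a number.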